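A few compounds are considered here, and "the series" means these few. Any claim that something is new, unique, unknown or untested is made for them only; others in the source may bear on it.

Measured in a functional assay on U-937 cells (Homo sapiens) for antiproliferative activity, read by MTT assay, with a stated time of 72 h; on this read-out lower numbers stand for stronger inhibition and higher numbers for weaker inhibition:
- compound 1 `COc1ccc(-c2noc(CCCCCCC(=O)NO)n2)cc1`: 3650 nM
- compound 2 `O=C(CCCCCCc1nc(-c2ccc(F)cc2)no1)NO`: 1930 nM
- compound 3 `Nc1ccccc1NC(=O)CCCCCCc1nc(-c2ccccc2)no1`: 730 nM

Of these three, compound 3 has the lowest number, and so the strongest inhibition. Going on to compound 4 `Nc1ccccc1NC(=O)CCCCCCc1nc(-c2cccc([N+](=O)[O-])c2)no1` brings one change, nitro in place of hydrogen on an aromatic carbon, turning phenyl into 3-nitrophenyl.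

Among the compounds with values here, only one measured step touches a substituent on an aromatic carbon: a 1.9-fold lower number from compound 1 to compound 2 (0.28 log units; within the scatter). Within the data shown here, that pair also differs from compound 3 elsewhere, and no measured compound carries a nitro group, so the guide is weak. In this assay, no shift beyond the scatter is therefore expected, and the estimated step is a 1.1-fold higher number from compound 3 to compound 4 (0.04 log units; within the scatter). For compound 4 the estimated value is 800 nM, within an expected range of 300 nM to 2100 nM.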

Compound 4, half-maximal inhibitory concentration: 2150 nM
For compound 4 the middle estimate is 2.7-fold (0.43 log units) below the measured one; measured number outside the range, above it.
By their numbers in this assay, from the lowest: compound 3; then compounds 2, 4 and 1 (each within the scatter of the next).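

Turning phenyl into 3-nitrophenyl gives a 2.9-fold higher number from compound 3 to compound 4 (0.47 log units; beyond the scatter) in this assay. Within the data shown here, the only earlier step on an aromatic carbon, between a different pair of compounds, stayed within the scatter, so this is the first sign that a change on the ring can matter, here by weakening inhibition. No measurement available here gives a reason for this loss.

Whether the loss belongs to nitro itself or to any group at this place stays open, since a methyl group or a chlorine atom here is not among the compounds shown. Other places on the phenyl ring also remain untested among these compounds.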